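Trading an Alkene Chain for Propyl at the Ring Amine

The source may report more compounds than this note shows. Statements on the series, on what has been measured and on what is new or still open speak of the compounds shown alone.

Compound 1 `COC1Cc2sccc2C2(CCN(Cc3ccc(F)cc3)CC2)O1`: 0.62 nM
Compound 2 `COC1Cc2sccc2C2(CCN(CC=C(C)C)CC2)O1`: 1 nM

Both share one core and differ only in the group on a saturated chain carbon bound to an amine nitrogen in a ring. In an assay on membranes from brain for displacement of a labelled ligand from Sigma non-opioid intracellular receptor 1 (Cavia porcellus) (a higher number here means a weaker inhibitor, a lower number a stronger inhibitor), compound 1 gives 0.62 nM and compound 2 gives 1 nM; the step of a 1.6-fold higher number from compound 1 to compound 2 (0.21 log units; within the scatter) is within the scatter, so compound 2 sits at the larger of the two numbers by a gap that carries no weight. Compound 3 `CCCCN1CCC2(CC1)OC(OC)Cc1sccc12` is not yet measured and differs from compound 2 by propyl in place of 2-methylprop-1-en-1-yl on a saturated chain carbon bound to an amine nitrogen in a ring. Among the compounds with values here, the only measured step at this position, a 1.6-fold higher number from compound 1 to compound 2 (0.21 log units; within the scatter), was within the scatter, so compound 3 is expected to show no shift beyond it, a 1.5-fold higher number from compound 2 to compound 3 (0.18 log units; within the scatter). Compound 3 is estimated in this assay at 1.5 nM, with a range from 0.5 nM to 5 nM.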

Compound 3, inhibition constant: 4.3 nM
Compound 3: middle estimate off by 2.9-fold (0.46 log units), on the low side, within the range that was stated.
By their numbers in this assay, from the lowest: compounds 1 and 2 (each within the scatter of the next); then compound 3.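

In this assay, within the data shown here, this position proves sensitive to the choice of group: propyl in place of 2-methylprop-1-en-1-yl gives a 4.3-fold higher number from compound 2 to compound 3 (0.63 log units; beyond the scatter), the first step here beyond the scatter. Propyl in place of 4-fluorophenyl gives a 6.9-fold higher number from compound 1 to compound 3 (0.84 log units; beyond the scatter), so compound 3 stands apart from two compounds that lie within the scatter of each other. No measurement is at hand to account for this difference.

The step to compound 3 removes the double bond and a carbon together, and the compounds shown do not separate the two. On these data alone, a saturated 2-methylpropyl group at this place would address that, while a longer straight chain remains open as well.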